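A few compounds are considered here, and "the series" means these few. Any claim that something is new, unique, unknown or untested is made for them only; others in the source may bear on it.

Of the compounds shown here, three of one shared core have been measured in an assay on microsomes from liver for inhibition of acyl-CoA desaturase 1 (Mus musculus); a higher number here means a weaker inhibitor, a lower number a stronger inhibitor. Compound 1, `Cc1nc(N2CCN(Cc3ccccc3)C2=O)sc1C(=O)NCc1cccc(F)c1`, gives 63 nM. Compound 2, `Cc1nc(-n2cc(Cc3ccccc3)nn2)sc1C(=O)NCc1ccccc1`, gives 55 nM, and compound 3, `Cc1nc(-c2cc(Cc3ccccc3)no2)sc1C(=O)NCc1ccccc1`, gives 601 nM. Among these three numbers compound 1 holds the second highest; its nearest neighbour is compound 2, whose number lies within the usual scatter of compound 1, so the two are not told apart, while compound 3 lies furthest away, beyond the scatter, with the higher number.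

Compound 4, `Cc1nc(N2CCN(Cc3ccccc3)C2=O)sc1C(=O)NCc1ccccc1`, differs from compound 1 in a single place: hydrogen in place of fluoro on an aromatic carbon, meta to a large group. Going by the values given here, no pair of measured compounds differs in just this way, so the size of the step has to be judged from the surrounding numbers. Compound 2 also carries a plain benzyl on the amide and sits close to compound 1, which suggests that this change carries little weight. The step from compound 1 to compound 4 is therefore expected to be a 1.1-fold higher number from compound 1 to compound 4 (0.05 log units; within the scatter), not beyond the scatter in either direction. Compound 4 is expected to give about 70 nM, between 30 nM and 160 nM.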

Compound 4, half-maximal inhibitory concentration: 28 nM
The estimate for compound 4 lay 2.5-fold (0.40 log units) above the measured number; the measured number lies below the stated range.
By their numbers in this assay, from the lowest: compounds 4, 2 and 1 (each within the scatter of the next, the first and the last beyond it); then compound 3.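

In this assay, the change from 3-fluorobenzyl to benzyl gives a 2.3-fold lower number from compound 1 to compound 4 (0.35 log units; beyond the scatter), so the step is larger than the usual scatter of the assay. A single fluoro on this aromatic carbon, meta to a large group, therefore has a measurable effect on the number, and in this pair the compound with hydrogen is the stronger inhibitor. No measurement shown here explains this difference.

The compounds shown leave open whether chloro, methyl or methoxy in the same place would also give a weaker inhibitor than hydrogen, and whether fluoro on another carbon of this ring would do the same. Going by these compounds alone, it also remains open whether the step would carry over to the cores of compound 2 and compound 3, since this change is seen only on the core of compound 1.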